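A few compounds are considered here, and "the series" means these few. Any claim that something is new, unique, unknown or untested is made for them only; others in the source may bear on it.

Measured so far:
compound 1, `CCCS(=O)(=O)Nc1ccc(F)c(C(=O)c2n[nH]c3ncc(-c4ccccc4OC)cc23)c1F`, gives 1.9% in an assay for binding affinity to dual specificity mitogen-activated protein kinase kinase 4 (Homo sapiens), read by KINOMEscan, tested at 100 nM; on this read-out lower numbers stand for a stronger effect and higher numbers for a weaker effect at the one concentration tested;
compound 2, `CCCS(=O)(=O)Nc1ccc(F)c(C(=O)c2n[nH]c3ncc(-c4cccc(OC)c4)cc23)c1F`, gives 6.3% in this assay;
compound 3, `CCCS(=O)(=O)Nc1ccc(F)c(C(=O)c2n[nH]c3ncc(-c4ccc(Cl)cc4Cl)cc23)c1F`, gives 22% in this assay.

Compound 2 stands second highest of the three numbers: its nearest neighbour is compound 1, and that step, a number 4.4 percentage points higher from compound 1 to compound 2 (within the scatter), lies within the scatter, so the two cannot be told apart. The furthest is compound 3, and that step, a number 15.7 percentage points higher from compound 2 to compound 3 (beyond the scatter), lies beyond the scatter.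

Compound 4, `CCCS(=O)(=O)Nc1ccc(F)c(C(=O)c2n[nH]c3ncc(-c4ccc(C(C)C)cc4)cc23)c1F`, has not yet been measured. It differs from compound 2 in one place: 4-isopropylphenyl in place of 3-methoxyphenyl on an aromatic carbon.

Among the compounds with values here, two measured steps bear on this. Moving the methoxy group within the ring, a number 4.4 percentage points higher from compound 1 to compound 2 (within the scatter), changed little. Replacing a methoxyphenyl by a ring without an oxygen, a number 20.1 percentage points higher from compound 1 to compound 3 (beyond the scatter) and a number 15.7 percentage points higher from compound 2 to compound 3 (beyond the scatter), raised the number modestly and beyond the scatter. Compound 4 likewise has no oxygen on that ring. A modest rise in this assay is therefore expected for compound 4, with step a number 7.7 percentage points higher from compound 2 to compound 4 (within the scatter), because compound 3 showed a number 15.7 percentage points higher from compound 2 to compound 3 (beyond the scatter) for a comparable loss of the methoxy group. The estimate for compound 4 is 14%, expected to fall between 4% and 40%.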

Compound 4, a percentage reported as activity, at one concentration (the size of the read-out at that concentration, not a potency): 17%
The estimate for compound 4 lay 3 percentage points below the measured number; the measured number falls inside the stated range.
By their numbers in this assay, from the lowest: compounds 1 and 2 (each within the scatter of the next); then compounds 4 and 3 (each within the scatter of the next).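

Compound 4 shows that the rise seen with compound 3 does not depend on chlorine: in this assay a ring carrying a single 4-isopropyl group gives a step of a number 10.7 percentage points higher from compound 2 to compound 4 (beyond the scatter) and also a step of a number 15.1 percentage points higher from compound 1 to compound 4 (beyond the scatter) when set against the two methoxyphenyl compounds. The two rings without oxygen cannot be told apart, with a number 5 percentage points lower from compound 3 to compound 4 (within the scatter) as the step between them, even though their substituents differ in kind and number. Across these four compounds, then, both methoxyphenyl rings give the lower numbers and both rings without oxygen give the higher ones, with no compound going against that split, and nothing measured here explains it.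

On these data alone, what stays open is whether the oxygen itself matters, for the isopropyl and methoxy groups also sit at different places on the ring, and 4-methoxyphenyl would separate those two changes directly. As far as these compounds go, it is equally open how this position would respond to a ring bearing an amine or a carboxylic acid, or to a longer chain at the 4-position of the ring.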